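The source may hold more compounds than are shown below. What is called first, only, known or untested is meant among the compounds shown, and "the series" means these compounds.

The series shares one core, varied only in the aryl group on the triazole nitrogen. In a functional assay on HepG2 cells (Homo sapiens) for antiproliferative activity, read by MTT assay, with a stated time of 48 h (a higher number here means a weaker inhibitor, a lower number a stronger inhibitor), compound 3 `N#CC1=C(N)Oc2c(N)cc3nc4ccccc4nc3c2C12C(=O)N(Cc1cnnn1-c1cc(Cl)ccc1Cl)c1ccccc12` gives 33100 nM; compound 2 `N#CC1=C(N)Oc2c(N)cc3nc4ccccc4nc3c2C12C(=O)N(Cc1cnnn1-c1ccccc1Br)c1ccccc12` gives 38000 nM, and a 1.1-fold lower number from compound 2 to compound 3 (0.06 log units; within the scatter) leaves the two within the scatter of each other. Compound 1 `Cc1cccc(-n2nncc2CN2C(=O)C3(C(C#N)=C(N)Oc4c(N)cc5nc6ccccc6nc5c43)c3ccccc32)c1` reaches only a limit of this assay, > 50000 nM, so no number is known for it (the limit of > 50000 nM in this assay, at which 1 of the 3 values shown sits).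

Compound 4 `N#CC1=C(N)Oc2c(N)cc3nc4ccccc4nc3c2C12C(=O)N(Cc1cnnn1-c1ccc(Cl)cc1[N+](=O)[O-])c1ccccc12` differs from compound 3 by 4-chloro-2-nitrophenyl in place of 2,5-dichlorophenyl on an aromatic nitrogen. All three measured steps bear on this change, since each swaps the aryl group on the same aromatic nitrogen: an at least 1.3-fold lower number from compound 1 to compound 2 (0.11 log units; that floor lies within the scatter) and an at least 1.5-fold lower number from compound 1 to compound 3 (0.17 log units; that floor lies within the scatter) are floors against a limit, and a 1.1-fold lower number from compound 2 to compound 3 (0.06 log units; within the scatter) is within the scatter. Going by the values given here, none shows movement beyond the scatter for a substituted phenyl at this position, and no step with a nitro group exists among the measured compounds.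

Compound 4 is therefore expected to stay near compound 3, with a 1.0-fold lower number from compound 3 to compound 4 (0.00 log units; within the scatter) as the estimated step and no direction beyond the scatter. The estimate for compound 4 is 33000 nM, between 14000 nM and 75000 nM.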

Compound 4, half-maximal inhibitory concentration: > 50000 nM
Compound 4: only a limit was reported; the forecaster's own chance of this, stated with the estimate: 30%; middle value at least 1.5-fold (0.18 log units) from the limit.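

In this assay compound 4 gives > 50000 nM, which is a limit and not a number, so a second aryl group on the triazole nitrogen now ends at that limit: the limit of > 50000 nM in this assay, at which 2 of the 4 values shown sit.

With the 4-chloro-2-nitrophenyl group, the comparisons are only floors, an at least 1.5-fold higher number from compound 3 to compound 4 (0.17 log units; that floor lies within the scatter) and an at least 1.3-fold higher number from compound 2 to compound 4 (0.11 log units; that floor lies within the scatter), so the nitro-bearing compound shows no gain over the halogenated aryl compounds, and no loss beyond the scatter is established. The step between compound 1 and compound 4 cannot be read, as both values are limits.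

No aryl group shown at this position has yet moved the number beyond the scatter, so how far this position can shift activity remains open. Also open, going by these compounds, is what an amine or a carboxylic acid on the phenyl ring would do, or a longer chain in place of the ring.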